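The compounds below may be only part of what the source reports. "The series", "measured", "known", "first", "only" and "open" are said of these compounds alone.

Measured compounds:

compound 1 `O=C(NC1CCN(Cc2cccc(Br)c2)CC1)c1cccc2ccccc12`: 66 nM
compound 2 `O=C(NC1CCN(Cc2ccc(C(F)(F)F)cc2)CC1)c1cccc2ccccc12`: 96 nM
compound 3 `O=C(NC1CCN(Cc2cccc(Cl)c2)CC1)c1ccc2ccccc2c1`: 54 nM

In an assay on isolated protein for displacement of a labelled ligand from D(4) dopamine receptor (Homo sapiens) (a higher number here means a weaker inhibitor, a lower number a stronger inhibitor), compound 3 gives 54 nM. It stands together with compound 1 and compound 2: its gaps to both are within the usual scatter, so the three cannot be told apart on these numbers. Compound 4 `O=C(NC1CCN(Cc2cccc(C(F)(F)F)c2)CC1)c1ccc2ccccc2c1` differs from compound 3 in one place: trifluoromethyl in place of chloro on an aromatic carbon. Among the measured compounds shown here, the one measured step that also exchanges a halogen for a trifluoromethyl group on that ring, a 1.5-fold higher number from compound 1 to compound 2 (0.16 log units; within the scatter), lay within the scatter. A step of a similar size, in no clear direction, is therefore expected here. Compound 4 is expected to give 65 nM, most likely between 30 nM and 140 nM. This estimate means an expected step of a 1.2-fold higher number from compound 3 to compound 4 (0.08 log units; within the scatter).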

Compound 4, inhibition constant: 103 nM
The estimate for compound 4 lay 1.6-fold (0.20 log units) below the measured number; low and high end bracket the measured number.
By their numbers in this assay, from the lowest: compounds 3, 1, 2 and 4 (each within the scatter of the next).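

In this assay, the exchange gives a 1.9-fold higher number from compound 3 to compound 4 (0.28 log units; within the scatter), so trifluoromethyl, with its 4 heavy atoms, takes the place of chloro, with its 1, without a difference that can be told from the scatter. Unlike the earlier step from compound 1 to compound 2, this one leaves the group's place on the ring unchanged, so only the group differs. On these data alone, whether an amine or a carboxylic acid at this position would also stay in this range remains open. So does how the same exchange reads on the core of compound 1. No measurement at hand gives a reason for this result.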